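The source may hold more compounds than are shown below. What is called first, only, known or untested is meant among the compounds shown, and "the series" means these compounds.

Measured compounds:
- compound 1, `OC(CCn1nc2c(Br)c(Br)c(Br)c(Br)c2n1)c1ccc(F)cc1`: 110%
- compound 2, `COc1cccc(C(O)CCn2nc3c(Br)c(Br)c(Br)c(Br)c3n2)c1`: 110%
- compound 3, `OC(CCn1nc2c(Br)c(Br)c(Br)c(Br)c2n1)c1ccccc1`: 122%

In a functional assay on CCRF-CEM cells (Homo sapiens) for antiproliferative activity, read by MTT assay, with a stated time of 24 h, tested at 12.5 uM (a lower number here means a stronger effect, a higher number a weaker effect of the compound at the concentration tested), compound 1 gives 110% and stands level with compound 2 at the digits shown, the two together being the lowest of the three numbers; compound 3 lies furthest off. The step of no change at the digits printed from compound 1 to compound 2 (within the scatter) is within the scatter, whereas a number 12 percentage points higher from compound 1 to compound 3 (beyond the scatter) and a number 12 percentage points higher from compound 2 to compound 3 (beyond the scatter) are each modest and beyond it.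

Compound 4, `CC(O)CCn1nc2c(Br)c(Br)c(Br)c(Br)c2n1`, has not yet been measured. It differs from compound 1 as follows: methyl in place of 4-fluorophenyl on a saturated chain carbon bound to an oxygen on a saturated carbon and a saturated chain carbon. Among the measured compounds shown here, no measured step removes the whole aromatic ring; the two steps beyond the scatter only exchange a single substituent on that ring for hydrogen, each raising the number by a modest amount. The change to compound 4 is larger than either, so its outcome is less certain, but nothing in the three numbers points towards a stronger effect. Compound 4 is therefore expected to give about 113% in this assay, within 98% to 128%, a step of a number 3 percentage points higher from compound 1 to compound 4 (within the scatter) that is estimated to stay within or only slightly beyond the scatter.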

Compound 4, a percentage reported as activity, at one concentration (the size of the read-out at that concentration, not a potency): 106%
Estimate against measurement, compound 4: 7 percentage points above; the range from low to high includes it.
By their numbers in this assay, from the lowest: compounds 4, 1 and 2 (each within the scatter of the next); then compound 3.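

In this assay, exchanging the aromatic ring at this position for methyl gives a number 4 percentage points lower from compound 1 to compound 4 (within the scatter) and a number 4 percentage points lower from compound 2 to compound 4 (within the scatter), so against these two aryl compounds the loss of the whole ring leaves no step beyond the scatter. Among the compounds shown here, the same exchange gives a number 16 percentage points lower from compound 3 to compound 4 (beyond the scatter), which leaves compound 3, with its unsubstituted phenyl, as the only compound apart from the others and goes against any reading that the size of the group alone sets the number. Nothing available accounts for these steps.

As far as these compounds go, whether an amine, a carboxylic acid or a longer chain in place of the methyl would move the number in either direction remains open. So does the outcome of replacing the hydroxyl-bearing carbon with a carbonyl, in compounds carrying either methyl or an aromatic ring.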